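Sulfamate series: aryl amide amine substituent and steryl-sulfatase inhibition

The source may report more compounds than this note shows. Statements on the series, on what has been measured and on what is new or still open speak of the compounds shown alone.

Measured so far:
compound 1 `CCN(Cc1ccccn1)c1ccc(C(=O)N2CCc3ccc(OS(N)(=O)=O)cc3C2)cc1`: 87.7%
compound 2 `CN(C)CCCN(Cc1ccccc1)c1cccc(C(=O)N2CCc3ccc(OS(N)(=O)=O)cc3C2)c1`: 26%
compound 3 `CCN(Cc1ccccc1)Cc1ccc(S(=O)(=O)N2CCc3ccc(OS(N)(=O)=O)cc3C2)cc1`: 31%

In an assay on HEK293 cells for inhibition of Steryl-sulfatase (Homo sapiens), tested at 1 uM (on this read-out lower numbers stand for a weaker effect and higher numbers for a stronger effect at the one concentration tested), compound 1 gives 87.7%, the highest of the three numbers and beyond the scatter from both compound 3 and compound 2. Compound 2 carries a benzyl group and gives 26%; compound 3 also carries a benzyl group and gives 31%. Among the measured compounds shown here, both differ from compound 1 in more than one place, so no single step is isolated.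

Compound 4 `CCCN(Cc1ccccc1)c1ccc(C(=O)N2CCc3ccc(OS(N)(=O)=O)cc3C2)cc1` is not yet measured. Change from compound 1: benzyl(propyl)amino in place of ethyl((pyridin-2-yl)methyl)amino on an aromatic carbon

Since the two benzyl-bearing compounds sit low, a moderate downward step a number 22.7 percentage points lower from compound 1 to compound 4 (beyond the scatter) is expected in this assay. Compound 4 is estimated at 65%, between 35% and 90%.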

Compound 4, a percentage reported as inhibition, at one concentration (the size of the read-out at that concentration, not a potency): 94.3%
Beside the measured number, compound 4's estimate is 29.3 percentage points below it; measured number above the stated range.
By their numbers in this assay, from the lowest: compounds 2 and 3 (each within the scatter of the next); then compounds 1 and 4 (each within the scatter of the next).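

In this assay, benzyl(propyl)amino in place of ethyl((pyridin-2-yl)methyl)amino, on an aromatic carbon para to a large group, gives a number 6.6 percentage points higher from compound 1 to compound 4 (within the scatter). At this position, the read-out therefore does not separate a six-membered aromatic ring of carbon only from one with a hetero atom, and a benzyl group is compatible with a high number, as compound 4 gives 94.3%. Nothing at hand accounts for this result.

A single concentration leaves any potency difference between compound 1 and compound 4 open. On these data alone, how a carboxylic acid or a longer chain on this amine nitrogen would read also remains open.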